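From Bromophenyl to Hydroxyphenyl on a Shared Core

The source may hold more compounds than are shown below. What is called first, only, known or untested is meant among the compounds shown, and "the series" means these compounds.

In a functional assay on HT-1080 cells (Homo sapiens) for cytotoxicity, read by MTT assay, with a stated time of 72 h (on this read-out higher numbers stand for weaker inhibition and lower numbers for stronger inhibition), compound 1 (`COc1cccc(/C=C2\CCC/C(=C\c3cc(OC)c(OC)c(OC)c3)C2=O)c1OC`) gives 2300 nM and compound 2 (`COc1cccc(/C=C2\CCC/C(=C\c3ccc(O)c(O)c3)C2=O)c1OC`) gives 4700 nM as its number. Compound 3 (`COc1ccc(/C=C2\CCC/C(=C\c3ccc(Br)cc3)C2=O)cc1OC`) gives 4300 nM and lies within the usual scatter of both. Compound 4 (`COc1ccc(/C=C2\CCC/C(=C\c3cccc(O)c3)C2=O)cc1OC`) has not been measured yet. It carries 3-hydroxyphenyl in place of 4-bromophenyl on a double-bonded chain carbon bound to a double-bonded ring carbon. Going by the values given here, no measured pair shows this change alone, so the evidence is thin. Compound 2 also carries hydroxyl groups, and its 4700 nM lies within the scatter of compound 3. What is expected in this assay is a 1.1-fold lower number from compound 3 to compound 4 (0.03 log units; within the scatter) and so no step beyond the scatter. The estimated value for compound 4 is 4000 nM (1500 nM to 10000 nM).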

Compound 4, half-maximal inhibitory concentration: 1700 nM
Compound 4: the middle estimate sits 2.4-fold (0.37 log units) above what was measured; the measured number falls inside the stated range.
By their numbers in this assay, from the lowest: compounds 4, 1, 3 and 2 (each within the scatter of the next, the first and the last beyond it).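

Placing 3-hydroxyphenyl in place of 4-bromophenyl on a double-bonded chain carbon bound to a double-bonded ring carbon gives a 2.5-fold lower number from compound 3 to compound 4 (0.40 log units; beyond the scatter) in this assay, the first listed step that clears the scatter. This shows that the group at this position can change the measured inhibition, with the hydroxyl-bearing compound inhibiting more strongly. Nothing available explains the shift. This single step cannot separate losing the bromine from gaining the hydroxyl. As far as these compounds go, whether an amine or a carboxylic acid in place of that hydroxyl would give a similar number remains open.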